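Benzyloxy to isobutoxy: compound 3 to compound 4

The compounds below may be only part of what the source reports. "The series", "measured", "known", "first", "only" and "open" are said of these compounds alone.

Measured so far in a physicochemical assay for lipophilicity, at pH 7.4; a higher number here means a more lipophilic compound, a lower number a more polar compound
compound 1 (`Cc1cc(C(N)=O)nn1Cc1cc(Cl)ccc1OCC(C)C`) at 3.1
compound 2 (`Cc1cc(C(=O)NN2CCCCC2)nn1Cc1cc(Cl)ccc1OCC(C)C`) at 3.3
compound 3 (`Cc1cc(NC(=O)C2CCCC2)nn1Cc1cc(Cl)ccc1OCc1ccccc1`) at 3.5

Compound 3 sits within the scatter of compound 2 and beyond the scatter from compound 1, at the upper end of this small set. Compound 4 (`Cc1cc(NC(=O)C2CCCC2)nn1Cc1cc(Cl)ccc1OCC(C)C`) is still unmeasured. The change from compound 3 is benzyloxy to isobutoxy (isopropyl in place of phenyl on a saturated chain carbon bound to an oxygen on an aromatic ring), that is, isopropyl in place of phenyl on a saturated chain carbon bound to an oxygen on an aromatic ring.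

Going by the values given here, no measured step makes this exchange. The only one (a number 0.20 log units higher from compound 1 to compound 2 (within the scatter)) puts piperidin-1-yl in place of hydrogen on an amide-type nitrogen, so it bears only indirectly. Compound 1 (3.1) and compound 2 (3.3) do carry isobutoxy, and both values lie close to that of compound 3. In this assay, no step beyond the scatter is therefore expected, with a slight lean downward. The estimated step is small (a number 0.10 log units lower from compound 3 to compound 4 (within the scatter)). The expected value for compound 4 is 3.4 within an estimated range (3.1 to 3.7).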

Compound 4, distribution coefficient: > 3.7
Compound 4 was reported as a limit (the forecaster's own chance of this, stated with the estimate: 1%); middle value at least 0.30 log units away from the limit.
By their numbers in this assay, from the lowest: compounds 1, 2 and 3 (each within the scatter of the next, the first and the last beyond it). At a limit, above all of these: compound 4.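

In this assay compound 4 gives > 3.7, which is a limit and not a number. Going by these compounds alone, the one exchange of phenyl for isopropyl on a saturated chain carbon bound to an oxygen on an aromatic ring gives a number at least 0.20 log units higher from compound 3 to compound 4 (that floor lies within the scatter), so losing the six-membered aromatic ring does not bring the number down here, though this floor alone does not establish a rise. On the aromatic carbon, the readings a number at least 0.40 log units higher from compound 2 to compound 4 (beyond the scatter) and a number at least 0.60 log units higher from compound 1 to compound 4 (beyond the scatter) set (cyclopentylcarbonyl)amino apart from (piperidin-1-yl)carbamoyl and from carbamoyl, and the upper size of all these steps stays unknown because of the ceiling: the limit of > 3.7 in this assay, at which 1 of the 4 values shown sits.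

From the compounds shown here alone, the effect of an amine or a carboxylic acid at the end of this chain remains open. So does the effect of a longer chain in place of isobutyl.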